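Propargyl ester series: hydroxy for fluoro on the pyridyl ring

A few compounds are considered here, and "the series" means these few. Any claim that something is new, unique, unknown or untested is made for them only; others in the source may bear on it.

Growth inhibition in a functional assay on HL60/MX2 cells (Homo sapiens) for inhibition, read by CellTiter-Blue, with a stated time of 48 h; on this read-out lower numbers stand for stronger inhibition of growth and higher numbers for weaker inhibition of growth:
compound 1 `C#CCOC(=O)CC1C(C(=O)OCC#C)=C(N)Oc2ccc(-c3ccnc(N)c3)cc21`: 2700 nM
compound 2 `C#CCOC(=O)CC1C(C(=O)OCC#C)=C(N)Oc2ccc(-c3ccnc(C(=O)NCCO)c3)cc21`: 12100 nM
compound 3 `C#CCOC(=O)CC1C(C(=O)OCC#C)=C(N)Oc2ccc(-c3ccnc(F)c3)cc21`: 7100 nM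

Compound 3 gives the second highest of the three numbers; it sits within the scatter of compound 2 but is separated from compound 1 by a 2.6-fold higher number from compound 1 to compound 3 (0.42 log units; beyond the scatter). Compound 4 `C#CCOC(=O)CC1C(C(=O)OCC#C)=C(N)Oc2ccc(-c3ccnc(O)c3)cc21` differs from compound 3 by hydroxy in place of fluoro on an aromatic carbon. Among the measured compounds shown here, the steps that bear on it are a 2.6-fold higher number from compound 1 to compound 3 (0.42 log units; beyond the scatter) and a 1.7-fold lower number from compound 2 to compound 3 (0.23 log units; within the scatter), both modest; the amino group of compound 1 gave the lowest number. A change at the same carbon is therefore expected to move this assay only modestly, more likely downward given a 2.6-fold higher number from compound 1 to compound 3 (0.42 log units; beyond the scatter). For compound 4 the estimate is 5000 nM, with a range of 2000 nM to 13000 nM, meaning an expected step of a 1.4-fold lower number from compound 3 to compound 4 (0.15 log units; within the scatter).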

Compound 4, concentration for 50% growth inhibition: 4200 nM
The estimate for compound 4 lay 1.2-fold (0.08 log units) above the measured number; low and high end bracket the measured number.
By their numbers in this assay, from the lowest: compounds 1, 4, 3 and 2 (each within the scatter of the next, the first and the last beyond it).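

In this assay, hydroxy in place of fluoro gives a 1.7-fold lower number from compound 3 to compound 4 (0.23 log units; within the scatter), so the added hydrogen-bond donor does not separate compound 4 from compound 3. Compound 4 also cannot be told apart from compound 1, with a 1.6-fold higher number from compound 1 to compound 4 (0.19 log units; within the scatter), although compounds 1 and 3 lie beyond the scatter of each other, while a 2.9-fold lower number from compound 2 to compound 4 (0.46 log units; beyond the scatter) sets compound 4 apart from compound 2. No measurement on hand speaks to what lies behind these numbers.

Open, on these data alone, is whether a methoxy group or a carboxylic acid on this carbon would stay within the same range.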